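Adding a fluorine to the aryl ring of compound 2

The source may hold more compounds than are shown below. What is called first, only, known or untested is meant among the compounds shown, and "the series" means these compounds.

Of the compounds shown here, two sharing one core have been measured in a functional assay on CHO cells for antagonist activity at corticotropin-releasing factor receptor 1 (Homo sapiens), read by cAMP accumulation; on this read-out lower numbers stand for stronger inhibition and higher numbers for weaker inhibition. Compound 1 `CCOc1ccc(-n2c(C)nc3c(NC(C4CC4)C4CC4)nc(C)nc32)cc1` gives 20 nM. Compound 2 `Cc1nc(NC(C2CC2)C2CC2)c2nc(C)n(-c3ccc(OC(F)F)cc3)c2n1` gives 5 nM. The only difference between them is the group on the ring oxygen, and a 4.0-fold lower number from compound 1 to compound 2 (0.60 log units; beyond the scatter). Among the measured compounds shown here, compound 2 therefore stands at the lower of the two numbers, with compound 1 as its only neighbour.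

Compound 3 `Cc1nc(NC(C2CC2)C2CC2)c2nc(C)n(-c3ccc(OC(F)F)cc3F)c2n1` is not yet measured. It differs from compound 2 in one place: fluoro in place of hydrogen on an aromatic carbon, on an aromatic carbon of a six-membered aromatic ring of carbon only, ortho to a large group and meta to a difluoromethoxy group.

For the measured compounds named here, no measured step involves a fluoro entering such a ring position; the single step known concerns the group on the oxygen and says nothing about a ring hydrogen. Going by the values given here, with no step bearing on the change, the expectation for compound 3 in this assay is a number close to that of compound 2, that is no change at the digits printed from compound 2 to compound 3 (within the scatter), which is not beyond the scatter. Compound 3 is accordingly estimated at 5 nM, with a range from 1.7 nM to 15 nM.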

Compound 3, inhibition constant: 7 nM
Compound 3: the middle estimate sits 1.4-fold (0.15 log units) below what was measured; the range from low to high includes it.
By their numbers in this assay, from the lowest: compounds 2 and 3 (each within the scatter of the next); then compound 1.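

In this assay, placing a fluoro on an aromatic carbon, ortho to a large group and meta to a difluoromethoxy group, gives a 1.4-fold higher number from compound 2 to compound 3 (0.15 log units; within the scatter), so this read-out cannot separate the two compounds. The earlier step concerned only the group on the ring oxygen, whereas this one is the first among the compounds shown to change the aromatic ring itself, and it shows that a ring hydrogen at this position can give way to a single fluorine atom with no change beyond the scatter. No supporting measurement is available to say why the number holds at this position, so the result stands as an observation only.

The compounds shown leave open whether this position would tolerate a chloro, a methyl or a methoxy group as it does a fluoro, since a single small atom says little about what a bigger group would do. They also leave open whether the same fluoro would behave alike on the ring of compound 1, which carries ethyl rather than difluoromethyl on the oxygen.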